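Ring-nitrogen substituent and microsomal half-life: notes

The source may hold more compounds than are shown below. What is called first, only, known or untested is meant among the compounds shown, and "the series" means these compounds.

Among the compounds with values here, in an ADME assay on microsomes (Rattus norvegicus) for metabolic stability (on this read-out lower numbers stand for a shorter-lived compound and higher numbers for a longer-lived compound), compound 3 `O=C(C1CCN(c2ccccc2)CC1)N1N=CCC1c1ccccc1` gives 0.25 h, the second highest of the three numbers so far. Compound 1 `O=C(c1ccccc1)N1CCC(C(=O)N2N=CCC2c2ccccc2)CC1` gives 0.0833 h in this assay, and compound 2 `CCC(=O)N1CCC(C(=O)N2N=CCC2c2ccccc2)CC1` gives 1.07 h. The steps recorded at the ring nitrogen are a 3.0-fold higher number from compound 1 to compound 3 (0.48 log units; beyond the scatter) and a 4.3-fold lower number from compound 2 to compound 3 (0.63 log units; beyond the scatter); the step of a 13-fold higher number from compound 1 to compound 2 (1.11 log units; beyond the scatter) shows how far two acyl groups at that position can lie apart.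

Compound 4 `O=C(c1cc[nH]n1)N1CCC(C(=O)N2N=CCC2c2ccccc2)CC1` changes the same position: (1H-pyrazol-3-yl)carbonyl in place of phenyl on an amine nitrogen in a ring. The change returns an acyl group to the ring nitrogen, so the two steps that reach compound 3 both bear on it, and they point in opposite directions: the benzoyl of compound 1 sits below compound 3, the propanoyl of compound 2 above it. Within the data shown here, no measured compound carries a heteroaromatic acyl group here, so the direction is open. The step expected is a 1.2-fold higher number from compound 3 to compound 4 (0.08 log units; within the scatter), with wide uncertainty either way. Compound 4 is estimated at 0.3 h, with a range from 0.08 h to 1.2 h.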

Compound 4, half-life: 0.317 h
The estimate for compound 4 lay 1.1-fold (0.02 log units) below the measured number; low and high end bracket the measured number.
By their numbers in this assay, from the lowest: compound 1; then compounds 3 and 4 (each within the scatter of the next); then compound 2.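

In this assay, (1H-pyrazol-3-yl)carbonyl on the amine nitrogen in a ring cannot be told apart from the phenyl of compound 3, with a 1.3-fold higher number from compound 3 to compound 4 (0.10 log units; within the scatter). The acyl groups at this position now number three, and changing the group on the carbonyl carbon gives a 3.8-fold higher number from compound 1 to compound 4 (0.58 log units; beyond the scatter) and a 3.4-fold lower number from compound 2 to compound 4 (0.53 log units; beyond the scatter). An aromatic ring on that carbonyl carbon therefore does not by itself set the number at the level of compound 1.

From the compounds shown here alone, it remains open whether the number of compound 2 belongs to open chains on the carbonyl carbon generally or to ethyl alone; butyl and cyclohexyl there would separate the two. Also open, going by these compounds, is what a methyl group on the pyrazole ring nitrogen would do to the number. No measurement on hand accounts for these differences.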